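The compounds below may be only part of what the source reports. "The series", "measured", "known", "first", "only" and "open" are said of these compounds alone.

In a functional assay on KB cells (Homo sapiens) for antiproliferative activity, with a stated time of 48 h (a higher number here means a weaker inhibitor, a lower number a stronger inhibitor), compound 1 (`C=CCN1c2c(N)nc(N)nc2CCC1CN(C)c1ccc(C(=O)N[C@@H](CCC(=O)O)C(=O)O)cc1`) gives > 100000 nM as its result, and this is a limit of the assay and not a number. Among the measured compounds shown here, compound 2 (`Cc1ccc(S(=O)(=O)N2c3c(N)nc(N)nc3CCC2CN(C)c2ccc(C(=O)N[C@@H](CCC(=O)O)C(=O)O)cc2)cc1`) gives 336 nM as the only true number so far. The next compound, compound 3 (`CN(CC1CCc2nc(N)nc(N)c2N1C=O)c1ccc(C(=O)N[C@@H](CCC(=O)O)C(=O)O)cc1`), carries formyl in place of (4-methylphenyl)sulfonyl on a nitrogen on an aromatic ring in a ring. For the measured compounds named here, one measured step concerns the same nitrogen: an at least 290-fold lower number from compound 1 to compound 2 (2.47 log units; beyond the scatter) when (4-methylphenyl)sulfonyl replaced allyl. That large step shows that the group on this nitrogen can matter greatly in this assay but says nothing directly about formyl. Compound 3 loses the group that compound 2 carries, so a weaker result is expected, though probably not one as extreme as the limit reached by compound 1. The expected change is a 6.0-fold higher number from compound 2 to compound 3 (0.77 log units; beyond the scatter) and remains only an estimate. Compound 3 is therefore expected to give 2000 nM (estimated range 150 nM to 40000 nM).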

Compound 3, half-maximal inhibitory concentration: > 130000 nM
Compound 3 was reported as a limit; the forecaster's own chance of this, stated with the estimate: 20%; middle value at least 65-fold (1.81 log units) from the limit.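

In this assay, putting formyl in place of (4-methylphenyl)sulfonyl on this nitrogen gives an at least 380-fold higher number from compound 2 to compound 3 (2.58 log units; beyond the scatter). Formyl keeps a hydrogen-bond acceptor and a double bond outside aromatic rings, yet the measurable activity of compound 2 is not kept, so these features alone are not enough at this position, and of the three groups shown on this nitrogen only (4-methylphenyl)sulfonyl gives a true number. Compound 3 ends at a limit of the assay and not at a number: the limit of > 130000 nM in this assay, at which 1 of the 3 values shown sits.

Compound 1 and compound 3 both stand at limits, so the step between them cannot be read and allyl and formyl cannot be put in order. From the compounds shown here alone, it also remains open which part of (4-methylphenyl)sulfonyl matters: methanesulfonyl would keep the sulfonyl without the aromatic ring, while 4-methylbenzoyl would keep the aromatic ring with a carbonyl in place of the sulfonyl.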